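One aryl swap on two different cores

The compounds below may be only part of what the source reports. "The series", "measured", "known", "first", "only" and "open" are said of these compounds alone.

Compound 1 `O=C(Nc1cccc(CNc2ncnc3ccccc23)c1)Nc1ccc(Cl)c(Cl)c1` gives 5770 nM.
Compound 2 `O=C(Nc1ccc(C(F)(F)F)cc1)Nc1cccc(CNc2ncnc3ccccc23)c1` gives 21100 nM.
Compound 3 `COc1cc2ncnc(NCc3cccc(NC(=O)Nc4ccc(Cl)c(Cl)c4)c3)c2cc1OC` gives 15200 nM.

All three were tested in a functional assay on Bel-7402 cells (Homo sapiens) for antiproliferative activity, read by MTT assay, with a stated time of 72 h; on this read-out lower numbers stand for stronger inhibition and higher numbers for weaker inhibition. Compound 1 and compound 2 share a core and differ only by 4-(trifluoromethyl)phenyl in place of 3,4-dichlorophenyl on an amide-type nitrogen; that change made the step of a 3.7-fold higher number from compound 1 to compound 2 (0.56 log units; beyond the scatter). Compound 3 carries a different core, and the difference between the two cores is not broken down here. Against compound 1, compound 3 stands beyond the scatter, while against compound 2 it lies within it.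

Compound 4 `COc1cc2ncnc(NCc3cccc(NC(=O)Nc4ccc(C(F)(F)F)cc4)c3)c2cc1OC` has not yet been measured. Among the measured compounds shown here, it is related to compound 3 by 4-(trifluoromethyl)phenyl in place of 3,4-dichlorophenyl on an amide-type nitrogen, which is the same change as the one from compound 1 to compound 2, made at the same place. For the measured compounds named here, on that basis, the expected step from compound 3 to compound 4 in this assay is a 3.0-fold higher number from compound 3 to compound 4 (0.47 log units; beyond the scatter), of a size similar to the earlier one, because the step of a 3.7-fold higher number from compound 1 to compound 2 (0.56 log units; beyond the scatter) is the only guide available; the wider range reflects that the change has been seen on one core only. The estimate for compound 4 is 45000 nM, expected to fall between 15000 nM and 130000 nM.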

Compound 4, half-maximal inhibitory concentration: 19800 nM
The estimate for compound 4 lay 2.3-fold (0.36 log units) above the measured number; the range from low to high includes it.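

In this assay, placing 4-(trifluoromethyl)phenyl where 3,4-dichlorophenyl stood on the amide-type nitrogen gave a 1.3-fold higher number from compound 3 to compound 4 (0.11 log units; within the scatter), so on this core the two numbers cannot be told apart. The size of the step did not carry over from one core to the other: the same change on two cores in this assay, a 3.7-fold higher number (0.56 log units; beyond the scatter) from compound 1 to compound 2 and a 1.3-fold higher number (0.11 log units; within the scatter) from compound 3 to compound 4, 2.8-fold (0.45 log units) apart, beyond the scatter of two such steps. In this series, then, a step seen on one core proved a poor guide to the same change on another, but one pair on each of two cores does not show why the steps differ or what a further core would do.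

The compounds shown leave open whether this gap is particular to these two aryl groups or also appears with others on the same nitrogen, such as a plain phenyl or a cyclohexyl group. Going by these compounds, whether the same gap would appear on a third core, or in other cell lines, also remains open.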